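Urea analogues on a shared quinoline-type scaffold: predicting a hydroxy variant

The compounds below may be only part of what the source reports. "The series", "measured", "known", "first", "only" and "open" are said of these compounds alone.

Measured compounds:
compound 1 `COc1cc(NC(C)CCCNC(=O)Nc2ccc(F)cc2)c2ncccc2c1`, 26000 nM
compound 2 `COc1cc(NC(C)CCCNC(=O)NNC(=O)Nc2ccc(Br)cc2)c2ncccc2c1`, 100 nM
compound 3 `COc1cc(NC(C)CCCNC(=O)Nc2ccc(C(F)(F)F)cc2)c2ncccc2c1`, 1900 nM

In a functional assay on MCF7 cells (Homo sapiens) for inhibition, read by MTT assay, with a stated time of 72 h (on this read-out lower numbers stand for stronger inhibition and higher numbers for weaker inhibition), compound 3 stands second highest of the three numbers; the nearest is compound 1 with a 14-fold lower number from compound 1 to compound 3 (1.14 log units; beyond the scatter), and the furthest is compound 2 with a 19-fold higher number from compound 2 to compound 3 (1.28 log units; beyond the scatter). Compound 4 `COc1cc(NC(C)CCCNC(=O)Nc2ccc(O)cc2)c2ncccc2c1` differs from compound 3 by hydroxy in place of trifluoromethyl on an aromatic carbon. Among the measured compounds shown here, the only step that bears on this position is the one from compound 1 to compound 3, a 14-fold lower number from compound 1 to compound 3 (1.14 log units; beyond the scatter), which shows that a change on this aromatic carbon can move the number well beyond the scatter. For the measured compounds named here, no hydroxy analogue has been measured, so the direction is uncertain; compound 4 is expected to show a 4.2-fold higher number from compound 3 to compound 4 (0.62 log units; beyond the scatter), a higher number. Compound 4 is therefore estimated at 8000 nM, within 1500 nM to 40000 nM.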

Compound 4, half-maximal inhibitory concentration: 5200 nM
Estimate against measurement, compound 4: 1.5-fold (0.19 log units) above; low and high end bracket the measured number.
By their numbers in this assay, from the lowest: compound 2; then compound 3; then compound 4; then compound 1.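

In this assay, the hydroxy group gives this aromatic carbon a third point (a 2.7-fold higher number from compound 3 to compound 4 (0.44 log units; beyond the scatter)) and also improves on fluoro (a 5.0-fold lower number from compound 1 to compound 4 (0.70 log units; beyond the scatter)), so it falls within the range set by fluoro and trifluoromethyl. None of these simple groups approaches compound 2 (a 52-fold higher number from compound 2 to compound 4 (1.72 log units; beyond the scatter)). Nothing at hand accounts for this order. Going by these compounds, what an amine or a carboxylic acid on the same aromatic carbon would give remains open. So does whether a bromo group on the shorter urea would come close to compound 2.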